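Same atoms, rearranged on the ring amine nitrogen

The compounds below may be only part of what the source reports. "The series", "measured", "known", "first", "only" and "open" are said of these compounds alone.

In a physicochemical assay for lipophilicity, read by HPLC, measured as chromatographic lipophilicity, at pH 7.4 (on this read-out higher numbers stand for higher lipophilicity and lower numbers for lower lipophilicity), compound 1 (`CC(C)(C)C(=O)N1N=CCC1c1cc(F)cc(F)c1`) gives 6.3 and compound 2 (`N#Cc1cnc(N2CCC(C(=O)N3N=CC[C@H]3c3cc(F)cc(F)c3)CC2)cn1`) gives 5.2. Among the measured compounds shown here, compound 2 is therefore the lower of the two numbers so far, and the gap to compound 1 lies beyond the usual scatter. For the measured compounds named here, these two compounds do not differ in one place, so the series offers no measured step to serve as a guide.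

Compound 3 (`N#Cc1cc(N2CCC(C(=O)N3N=CC[C@H]3c3cc(F)cc(F)c3)CC2)ncn1`) has the same atoms as compound 2, joined differently: a group of 8 heavy atoms (5 carbon, 3 nitrogen; one six-membered aromatic ring with 2 hetero atoms) in place of a group of 8 heavy atoms (5 carbon, 3 nitrogen; one six-membered aromatic ring with 2 hetero atoms), on an amine nitrogen in a ring. The 5-cyanopyrazin-2-yl group leaves, and the incoming group sits on the same amine nitrogen in a ring.

With the counted features unchanged, the anchor is compound 2 at 5.2. In this assay a slight fall is expected, but none beyond the scatter. The estimated change is a number 0.10 log units lower from compound 2 to compound 3 (within the scatter). For compound 3 the expected value is 5.1, with an estimated range of 4.7 to 5.5.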

Compound 3, distribution coefficient: 5
Compound 3: the middle estimate sits 0.10 log units above what was measured, and the stated range covers the measured number.
By their numbers in this assay, from the lowest: compounds 3 and 2 (each within the scatter of the next); then compound 1.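

In this assay the swap on the amine nitrogen in a ring, from the 5-cyanopyrazin-2-yl group to its isomer, gives a number 0.20 log units lower from compound 2 to compound 3 (within the scatter) and so does not separate the two compounds. Among the compounds shown here, this is the first step that can be read at this position, and it shows that, for this one pair, rearranging the atoms of the group while its counted features stay the same leaves the read-out within the scatter. No measurement at hand bears on why the two numbers lie so close.

Going by these compounds, whether this holds for groups of different make-up on the same nitrogen, such as a plain phenyl ring or an acetyl group, stays open. Also open, on these data alone, is what happens when the nitrile on the aromatic ring gives way to a carboxylic acid or a primary amine.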